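Replacing the iodophenyl of compound 1 with a methylphenyl

The source may hold more compounds than are shown below. What is called first, only, known or untested is meant among the compounds shown, and "the series" means these compounds.

Of the compounds shown here, three of one shared core have been measured in a functional assay on the whole organism (strain albino) with Mus musculus as the target, at a dose of 100 mg/kg by the intraperitoneal route; a higher number here means more inhibition at the dose given (going by the name of the read-out), a lower number less inhibition. Compound 1 `O=C(Nc1ccc(I)cc1)Nn1c(-c2ccccc2)nc2ccccc2c1=O` gives 60% in this assay, the highest of the three numbers, although its gaps to compound 3 and to compound 2 are both within the scatter. Compound 2 `CCOc1ccc(NC(=O)Nn2c(CC)nc3ccccc3c2=O)cc1` gives 50% in this assay, and compound 3 `CCc1nc2ccccc2c(=O)n1NC(=O)Nc1ccc(F)cc1` gives 51% in this assay. Among the measured compounds shown here, the only single-point step between measured compounds, a number 1 percentage points higher from compound 2 to compound 3 (within the scatter), changes the group on the aryl urea, much as the step to compound 4 `Cc1ccccc1NC(=O)Nn1c(-c2ccccc2)nc2ccccc2c1=O` does. For the measured compounds named here, that step is the sole guide here: 2-methylphenyl in place of 4-iodophenyl on an amide-type nitrogen. Going by the values given here, with the one comparable step lying within the scatter, the account expects no step beyond the scatter from compound 1 to compound 4 in this assay, and accordingly estimates a number 5 percentage points lower from compound 1 to compound 4 (within the scatter). Compound 4 is therefore estimated to give 55% in this assay, within a range from 35% to 75%.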

Compound 4, a percentage reported as inhibition, in the whole organism at one dose (the size of the read-out at that dose, not a potency): 59%
The estimate for compound 4 lay 4 percentage points below the measured number; the measured number falls inside the stated range.
By their numbers in this assay, from the lowest: compounds 2, 3, 4 and 1 (each within the scatter of the next).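

In this assay, the exchange of 4-iodophenyl for 2-methylphenyl on an amide-type nitrogen gives a number 1 percentage points lower from compound 1 to compound 4 (within the scatter) on the core of compound 1. Compound 2 and compound 3 showed a change on the aryl urea only with an ethyl group on the shared core, whereas this step shows that, with a phenyl group there instead, the aryl urea also accepts a different group with no change beyond the scatter, even as iodine leaves and an all-carbon group enters. No evidence bears on why the two groups give such close numbers.

The compounds shown leave open what a pyridine ring in place of the aryl group, or an amine or a carboxylic acid on it, would do. Also open, going by these compounds, is whether 2-methylphenyl would read the same with an ethyl group or a longer chain in place of the phenyl group on the core.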